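Compound 3: hydrogen in place of methoxy

A few compounds are considered here, and "the series" means these few. Any claim that something is new, unique, unknown or untested is made for them only; others in the source may bear on it.

Going by the values given here, in a functional assay on HCT-116 cells (Homo sapiens) for antiproliferative activity, read by MTT assay, with a stated time of 72 h (a higher number here means a weaker inhibitor, a lower number a stronger inhibitor), compound 1 `COc1ccc(N2C(=O)COc3ccc(-c4cnc(Cl)c(NS(=O)(=O)c5ccc(F)cc5)c4)cc32)cc1` gives 30100 nM, the only actual number so far. Compound 2 `Cc1ccc(N2C(=O)COc3ccc(-c4cnc5ccccc5c4)cc32)cc1` reads > 40000 nM, which is a limit of the assay. Compound 3 `O=C1COc2ccc(-c3cnc(Cl)c(NS(=O)(=O)c4ccc(F)cc4)c3)cc2N1c1ccccc1` has hydrogen in place of methoxy on an aromatic carbon, para to a large group: hydrogen in place of methoxy on an aromatic carbon. Among the compounds with values here, no measured step is available as a guide, so no shift beyond the scatter is expected in this assay, in either direction. The estimated change is a 1.0-fold lower number from compound 1 to compound 3 (0.00 log units; within the scatter). Compound 3 is expected at 30000 nM, within an estimated range of 15000 nM to 50000 nM.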

Compound 3, half-maximal inhibitory concentration: 39800 nM
For compound 3 the middle estimate is 1.3-fold (0.12 log units) below the measured one; the measured number falls inside the stated range.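

In this assay the change from 4-methoxyphenyl to phenyl gives a 1.3-fold higher number from compound 1 to compound 3 (0.12 log units; within the scatter), so at this position, para to a large group, methoxy can be lost without a shift beyond the scatter. Going by these compounds alone, this is the first step that can be read, but it sits close to the top of the measurable range, which restricts what it can reveal: the limit of > 40000 nM in this assay, at which 1 of the 3 values shown sits.

Going by these compounds, whether an amine, a carboxylic acid or a longer chain at this position would move the number beyond the scatter stays open. Also open, on these data alone, is whether the same change stays within the scatter on a compound with a much lower number.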